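A thiophene in place of naphthalene: an untested change

The source may report more compounds than this note shows. Statements on the series, on what has been measured and on what is new or still open speak of the compounds shown alone.

Three measured compounds share one core and differ only in a single group on one aromatic carbon. Compound 1 `COc1ccc(C2CC(c3ccc4ccccc4c3)=NN2C2=NC(=O)/C(=C3/C(=O)Nc4ccc(C)cc43)S2)cc1` carries a methyl there and in a functional assay on U-87MG ATCC cells for antiproliferative activity against U-87 MG (Homo sapiens), read by MTT assay, with a stated time of 72 h (a higher number here means that more compound is needed for the effect, a lower number that less compound is needed), compound 1 gives 230 nM. Compound 2 `COc1ccc(C2CC(c3ccc4ccccc4c3)=NN2C2=NC(=O)/C(=C3/C(=O)Nc4ccc(Cl)cc43)S2)cc1` carries a chloro, and in this assay compound 2 gives 380 nM, the second highest of the three numbers. Compound 3 `COc1ccc(C2CC(c3ccc4ccccc4c3)=NN2C2=NC(=O)/C(=C3/C(=O)Nc4ccc(OC)cc43)S2)cc1` carries a methoxy, and compound 3 gives 670 nM. The steps among them are small: a 1.7-fold higher number from compound 1 to compound 2 (0.22 log units; within the scatter), a 1.8-fold higher number from compound 2 to compound 3 (0.25 log units; within the scatter), and only a 2.9-fold higher number from compound 1 to compound 3 (0.46 log units; beyond the scatter).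

Compound 4 `COc1ccc(C2CC(c3cccs3)=NN2C2=NC(=O)/C(=C3/C(=O)Nc4ccc(Cl)cc43)S2)cc1` keeps the chloro of compound 2 but changes a different part of the molecule: thiophen-2-yl in place of naphthalen-2-yl on a carbon with a double bond to nitrogen. Among the measured compounds shown here, none of the measured steps touches this position, so nothing here shows how the core responds to a change at that carbon. For the measured compounds named here, the only guide is that the three measured values all lie close together.

Going by the values given here, with no step bearing on the change, the expectation for compound 4 is drawn wide, and the number is estimated as a 2.1-fold higher number from compound 2 to compound 4 (0.32 log units; beyond the scatter). Compound 4 is therefore expected to give about 800 nM in this assay, somewhere between 250 nM and 2500 nM.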

Compound 4, half-maximal effective concentration: 5760 nM
For compound 4 the middle estimate is 7.2-fold (0.86 log units) below the measured one, and the stated range ends below it.
By their numbers in this assay, from the lowest: compounds 1, 2 and 3 (each within the scatter of the next, the first and the last beyond it); then compound 4.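

In this assay, thiophen-2-yl in place of naphthalen-2-yl gives a 15-fold higher number from compound 2 to compound 4 (1.18 log units; beyond the scatter), whereas the largest step among the methyl, chloro and methoxy compounds is a 2.9-fold higher number from compound 1 to compound 3 (0.46 log units; beyond the scatter). Among the compounds shown here, the number in this assay therefore depends strongly on the group at this carbon with a double bond to nitrogen, far more than the earlier compounds, which vary only a single group elsewhere, could reveal. This one swap changes several things at once, replacing 10 heavy atoms with 5, two six-membered aromatic rings of carbon only with one five-membered aromatic ring, and adding a sulfur, and no measurement shown separates these changes or explains the step.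

The compounds shown leave open whether the ring count, the atom count or the sulfur matters most, a question that a phenyl or a furan-2-yl group at this carbon could help to answer. They also leave open whether the same swap would have a similar effect with the methyl of compound 1 or the methoxy of compound 3 in place of the chloro.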